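Meta-substituted dienone series: replacing nitro with methyl

The compounds below may be only part of what the source reports. "The series", "measured", "known", "first", "only" and "open" are said of these compounds alone.

Compound 1, `CC1=CCCC(C)(C)C1/C=C/C(=O)/C=C/c1cccc(C(F)(F)F)c1`: in a functional assay on LNCaP cells (Homo sapiens) for cytotoxicity, read by MTT assay, with a stated time of 72 h (on this read-out higher numbers stand for weaker inhibition and lower numbers for stronger inhibition), compound 1 gives 1000 nM.
Compound 2, `CC1=CCCC(C)(C)C1/C=C/C(=O)/C=C/c1ccccc1F`: in this assay compound 2 gives 1600 nM.
Compound 3, `CC1=CCCC(C)(C)C1/C=C/C(=O)/C=C/c1cccc([N+](=O)[O-])c1`: in this assay compound 3 gives 3300 nM.

Among the compounds with values here, compound 3 stands highest of the three numbers measured so far; compound 2 lies nearest to it and compound 1 furthest, both gaps beyond the scatter. Compound 4, `CC1=CCCC(C)(C)C1/C=C/C(=O)/C=C/c1cccc(C)c1`, differs from compound 3 by methyl in place of nitro on an aromatic carbon. Within the data shown here, the one measured step that bears on this position is a 3.3-fold higher number from compound 1 to compound 3 (0.52 log units; beyond the scatter), showing that the group at this position moves the number by a modest amount. Among the measured compounds shown here, no measured step exchanges nitro for methyl, and no other measured pair varies only this group, so the direction for compound 4 rests on that single step alone. Since the change from nitro back to a small carbon group undoes the kind of exchange that raised the number, a modest step downward is expected for compound 4, a 2.2-fold lower number from compound 3 to compound 4 (0.34 log units; beyond the scatter), though a result within the scatter would not be surprising. Compound 4 is estimated at 1500 nM in this assay, with a range from 600 nM to 4000 nM.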

Compound 4, half-maximal inhibitory concentration: 12200 nM
Compound 4: middle estimate off by 8.1-fold (0.91 log units), on the low side; measured number above the stated range.
By their numbers in this assay, from the lowest: compounds 1 and 2 (each within the scatter of the next); then compound 3; then compound 4.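

In this assay, methyl does not track trifluoromethyl at this aromatic carbon: a 12-fold higher number from compound 1 to compound 4 (1.09 log units; beyond the scatter) is the largest step in the set, and a 3.7-fold higher number from compound 3 to compound 4 (0.57 log units; beyond the scatter) puts nitro between the two groups rather than at the weak end. Within the data shown here, compound 4 is therefore the weakest of the four, including against the 2-fluorophenyl compound, with a 7.6-fold higher number from compound 2 to compound 4 (0.88 log units; beyond the scatter) for that change, so this position spans a wider range than the single earlier step showed. Nothing available accounts for this order of the groups.

On these data alone, whether an amine, a methoxy group or a fluorine at this same aromatic carbon would fall nearer compound 1 or compound 4 remains open. Also open, as far as these compounds go, is whether the order trifluoromethyl, nitro, methyl holds at other carbons of the ring.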